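Swapping 2-hydroxyethyl for hydroxy in a cytotoxicity test

This account rests on a few compounds, and the source may have more. Where it says the series, first, only, none or still open, it means among the compounds named here.

Compound 1 `Nc1ncc(F)c2c1ncn2[C@@H]1C[C@H](CO)[C@@H](O)[C@H]1O` gives > 100000 nM
Compound 2 `Nc1ncc(F)c2c1ncn2[C@@H]1C[C@H](CCO)[C@@H](O)[C@H]1O` gives > 100000 nM

In an ADME assay on HEK293 cells (Homo sapiens) for cytotoxicity (a lower number here means that less compound is tolerated, a higher number that more compound is tolerated), compound 2 gives > 100000 nM as a limit of the assay, not a number. Compound 1 stands at a limit too, so the record so far is simply the limit of > 100000 nM in this assay, at which 2 of the 2 values shown sit, and no true value is known. Compound 3 `Nc1ncc(F)c2c1ncn2[C@@H]1C[C@H](O)[C@@H](O)[C@H]1O` carries hydroxy in place of 2-hydroxyethyl on a saturated ring carbon and is still to be measured. Going by the values given here, the one measured step bearing on this change is a step that the two limits leave unreadable from compound 1 to compound 2 and it offers no size to carry over. With no sign of a shift so far, no step beyond the scatter is expected in this assay in either direction. The expected change is a number no higher from compound 2 to compound 3 (the limit leaves the size open) in this estimate. Compound 3 is estimated at 100000 nM with a range from 40000 nM to 200000 nM and may well prove only a limit.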

Compound 3, half-maximal cytotoxic concentration: > 100000 nM
Compound 3 ended at the assay's limit; the forecaster's own chance of this, stated with the estimate: 85%; the middle value lies on the limit itself.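

No step among compound 1, compound 2 and compound 3 can be read, because all three stop at the same limit of the assay rather than giving numbers: the limit of > 100000 nM in this assay, at which 3 of the 3 values shown sit.

Going by these compounds, the true values stay open, and so does whether swapping hydroxy, hydroxymethyl and 2-hydroxyethyl changes cytotoxicity at all.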